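Adding a Second Chloro Group to Compound 2

This account rests on a few compounds, and the source may have more. Where it says the series, first, only, none or still open, it means among the compounds named here.

Compound 1 `FC(F)(F)c1ccccc1-c1nc(NCc2ccc(Cl)cc2)c2ccccc2n1` gives 4800 nM in an assay on a protein complex for inhibition of ubiquitin carboxyl-terminal hydrolase 1/WD repeat-containing protein 48 (Homo sapiens), read by fluorescence; a lower number here means a stronger inhibitor, a higher number a weaker inhibitor. Compound 2 `FC(F)(F)c1ccccc1-c1nc(NCc2ccc(-c3ccc(Cl)cc3)cc2)c2ccccc2n1` gives 3600 nM in this assay. Among the measured compounds shown here, the one change between them, 4-chlorophenyl in place of chloro on an aromatic carbon, produced a 1.3-fold lower number from compound 1 to compound 2 (0.12 log units; within the scatter), so the two numbers sit within the scatter of each other and neither compound can be set apart from the other. Compound 2 is therefore one of two closely similar numbers, nothing more.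

Compound 3 `FC(F)(F)c1ccccc1-c1nc(NCc2ccc(-c3ccc(Cl)c(Cl)c3)cc2)c2ccccc2n1` differs from compound 2 by chloro in place of hydrogen on an aromatic carbon, which turns the 4-chlorophenyl into a 3,4-dichlorophenyl. For the measured compounds named here, no measured step adds a chloro to this outer ring; the only measured step, a change at a different place, stayed within the scatter. Without a step that bears directly, the expectation for compound 3 in this assay is a 1.2-fold lower number from compound 2 to compound 3 (0.08 log units; within the scatter), no shift beyond the scatter, with an estimated value of 3000 nM, ranging from 1200 nM to 7500 nM.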

Compound 3, half-maximal inhibitory concentration: 2200 nM
Beside the measured number, compound 3's estimate is 1.4-fold (0.13 log units) above it; the range from low to high includes it.
By their numbers in this assay, from the lowest: compounds 3, 2 and 1 (each within the scatter of the next, the first and the last beyond it).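

On the outer ring, the chloro added in place of hydrogen gives a 1.6-fold lower number from compound 2 to compound 3 (0.21 log units; within the scatter) in this assay, so this single change does not set compound 3 apart from compound 2. Measured against the lone chloro of compound 1, however, the 3,4-dichlorophenyl gives a 2.2-fold lower number from compound 1 to compound 3 (0.34 log units; beyond the scatter), the only step among these compounds that passes the scatter, and only modestly. No measurement is available that could explain this small difference.

From the compounds shown here alone, it remains open whether a group other than chloro on this outer ring, such as an amine, a carboxylic acid or a methoxy group, would give a clearer step away from compound 2. Going by these compounds, it is also open whether a larger step would appear if the outer ring were replaced altogether.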